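One measured step and an estimate for compound 3

The compounds below may be only part of what the source reports. "The series", "measured", "known", "first", "only" and "open" are said of these compounds alone.

Compound 1 `COc1ccc(S(=O)(=O)Nc2ccc3oc(-c4ccc(NC(=O)c5ccc(Cl)s5)cc4)nc3c2)cc1` gives 1900 nM
Compound 2 `COc1ccc(S(=O)(=O)Nc2ccc3oc(-c4ccc(NS(=O)(=O)c5cc(F)ccc5OC)cc4)nc3c2)cc1` gives 15000 nM

In a functional assay on HT-29 cells (Homo sapiens) for cytotoxicity, read by resazurin assay, with a stated time of 48 h (on this read-out higher numbers stand for an effect only at larger amounts of compound and lower numbers for an effect already at smaller amounts), compound 2 stands higher of the two, and nothing else has been measured. Going by the values given here, the only measured step is a 7.9-fold higher number from compound 1 to compound 2 (0.90 log units; beyond the scatter), a modest one beyond the scatter, made on a nitrogen on an aromatic ring. Compound 3 `COc1ccc(S(=O)(=O)Nc2ccc3oc(-c4ccc(NC(=O)C5CCN(C(C)=O)CC5)cc4)nc3c2)cc1` keeps the shared core and changes the group on that same nitrogen: a group of 11 heavy atoms (8 carbon, 1 nitrogen, 2 oxygen; one six-membered non-aromatic ring with 1 hetero atom) in place of a group of 12 heavy atoms (7 carbon, 3 oxygen, 1 fluorine, 1 sulfur; one six-membered aromatic ring of carbon only), on a nitrogen on an aromatic ring. That step bears on this change only in part. Among the compounds with values here, compound 1 also has a carbonyl on that nitrogen, but no measured compound carries the (1-acetylpiperidin-4-yl)carbonyl group itself. Reading a 7.9-fold higher number from compound 1 to compound 2 (0.90 log units; beyond the scatter) backwards, a move to a lower number is expected, smaller than that step. The expected change is a 2.5-fold lower number from compound 2 to compound 3 (0.40 log units; beyond the scatter) in this assay. Compound 3 is estimated at 6000 nM, with an expected range from 2000 nM to 20000 nM.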

Compound 3, half-maximal effective concentration: 16000 nM
Compound 3: middle estimate off by 2.7-fold (0.43 log units), on the low side; measured number inside the range.
By their numbers in this assay, from the lowest: compound 1; then compounds 2 and 3 (each within the scatter of the next).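

In this assay, the (1-acetylpiperidin-4-yl)carbonyl group on this nitrogen reads level with the group it replaces (a 1.1-fold higher number from compound 2 to compound 3 (0.03 log units; within the scatter)), so two quite different groups give numbers within the scatter of each other. With the carbonyl kept on the nitrogen, 1-acetylpiperidin-4-yl in place of 5-chlorothiophen-2-yl gives an 8.4-fold higher number from compound 1 to compound 3 (0.93 log units; beyond the scatter) and so shows that the carbonyl alone does not go with the lower number of compound 1. Nothing measured here explains these numbers.

On these data alone, it remains open whether the lower number of compound 1 goes with the chlorine or with the thiophene ring, which a plain thiophen-2-yl or a phenyl on the carbonyl carbon would test. As far as these compounds go, it is also open whether the acetyl matters, which the free piperidine amine would test.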